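Adding methoxy to a compound at the assay limit

This account rests on a few compounds, and the source may have more. Where it says the series, first, only, none or still open, it means among the compounds named here.

Measured in a functional assay on PC-3 cells (Homo sapiens) for cytotoxicity, read by WST assay, with a stated time of 24 h; on this read-out lower numbers stand for stronger inhibition and higher numbers for weaker inhibition:
Compound 1 `N#C/C(=C\c1c[nH]c2cc(F)ccc12)C(=O)c1c[nH]c2cc(F)ccc12`: > 50000 nM, a limit
Compound 2 `N#C/C(=C\c1c[nH]c2cc(F)ccc12)C(=O)c1c[nH]c2ccccc12`: > 50000 nM, a limit
Not yet measured: compound 3 `COc1ccc2c(C(=O)/C(C#N)=C/c3c[nH]c4cc(F)ccc34)c[nH]c2c1`

In this assay compound 2 stands at a limit, > 50000 nM, so it has no exact number. Compound 1 also stands at a limit, > 50000 nM. All the evidence so far is the limit of > 50000 nM in this assay, at which 2 of the 2 values shown sit. Among the measured compounds shown here, the one measured step is a step that the two limits leave unreadable from compound 1 to compound 2, and its size cannot be read.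

Compound 3 carries methoxy in place of hydrogen on an aromatic carbon. For the measured compounds named here, no measured step involves this group, so the data give no size for the change. Only a modest move towards stronger inhibition is expected, and a further limit is the likeliest result. The expected step is an at least 1.1-fold lower number from compound 2 to compound 3 (0.04 log units; that floor lies within the scatter), an estimate only. Compound 3 is estimated at 45000 nM, with an expected range from 15000 nM to 100000 nM.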

Compound 3, half-maximal inhibitory concentration: 36000 nM
Estimate against measurement, compound 3: 1.3-fold (0.10 log units) above; the measured number falls inside the stated range.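

In this assay compound 3 gives the first exact number shown, so this position, on an aromatic carbon meta to a fused ring and para to a fused ring, now has a measured reading. Methoxy in place of hydrogen gives an at least 1.3-fold lower number from compound 2 to compound 3 (0.14 log units; that floor lies within the scatter), and methoxy in place of fluoro gives an at least 1.3-fold lower number from compound 1 to compound 3 (0.14 log units; that floor lies within the scatter); each is only a floor, with a limit at one end, and neither floor shows a change beyond the scatter. The other values remain at a limit: the limit of > 50000 nM in this assay, at which 2 of the 3 values shown sit.

The step between compound 1 and compound 2 cannot be read, and compound 3 has no second exact value to be compared with. From the compounds shown here alone, whether an amine, a hydroxyl or a longer alkoxy chain at this position would give a step beyond the scatter stays open.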